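The compounds below may be only part of what the source reports. "The series", "measured", "known", "first", "only" and "open" are said of these compounds alone.

Working notes on a short set of brominated analogues that share one core and have been run in a functional assay on DLD-1 cells (Homo sapiens) for cytotoxicity, read by MTT assay, with a stated time of 96 h; a lower number here means a stronger inhibitor, a higher number a weaker inhibitor. Compound 1 `OCc1cc(O)c(O)c(Br)c1` gives 51500 nM in this assay. Compound 2 `O=Cc1cc(Br)c(O)c(O)c1Br` gives 31000 nM, and compound 3 `CCOCc1cc(O)c(O)c(Br)c1Br` gives 13500 nM. Of the three numbers, compound 1 holds the highest. Its gap to compound 2 is within the usual scatter, so no order between those two can be read. Its gap to compound 3 lies beyond the scatter, so compound 3 returns the clearly lower number of that pair. Among the measured compounds shown here, no two of the measured compounds differ in only one place, so no single-point step can be extracted from them.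

The next compound, compound 4 `CCCOCc1cc(O)c(O)c(Br)c1`, differs from compound 1 in one place: propyl in place of hydrogen on an oxygen on a saturated carbon. For the measured compounds named here, no measured pair isolates this change. Compound 3, with its value of 13500 nM, differs from compound 1 in more than one place, so its lower number cannot be credited to any one of them. For compound 4 a step toward a lower number, of moderate size and possibly just beyond the scatter, is expected as a 2.3-fold lower number from compound 1 to compound 4 (0.37 log units; beyond the scatter). Compound 4 is therefore estimated at 22000 nM, with a range from 8000 nM to 55000 nM.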

Compound 4, half-maximal inhibitory concentration: 26300 nM
Beside the measured number, compound 4's estimate is 1.2-fold (0.08 log units) below it, and the stated range covers the measured number.
By their numbers in this assay, from the lowest: compounds 3, 4, 2 and 1 (each within the scatter of the next, the first and the last beyond it).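

Hydroxy to propoxy gives the series its first single-place step: in this assay the change reads as a 2.0-fold lower number from compound 1 to compound 4 (0.29 log units; within the scatter) and stays within the scatter, so no order can be read between these two compounds. At this position, on the oxygen on a saturated carbon, propyl can therefore stand in place of hydrogen without a readable change in the number, and compound 4 gives 26300 nM in the same micromolar range as the parent. Nothing in hand offers an explanation for this flat result.

On these data alone, whether a longer chain such as hexyl, or an amine or a carboxylic acid at this position, would carry the number beyond the scatter remains open. Compound 3 gives 13500 nM and differs in one place from no other compound shown, so its number cannot yet be tied to any single change.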